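Swapping the amide side chain for a substituted pyrazole

The source may hold more compounds than are shown below. What is called first, only, known or untested is meant among the compounds shown, and "the series" means these compounds.

Of the compounds shown here, three sharing one core have been measured in an assay on cells for positive allosteric modulation of Cystic fibrosis transmembrane conductance regulator variant F508del (Homo sapiens), with stated times of 10 min and 7 s, in the presence of a further agent that is not named here; a lower number here means that less compound is needed, a higher number that more compound is needed for the effect. Compound 1 `CC1(C)Cc2c(sc(NC(=O)c3cccnc3O)c2C(N)=O)C(C)(C)O1` gives 190 nM. Compound 2 `CC1(C)Cc2c(sc(NC(=O)c3ccn[nH]3)c2C(N)=O)C(C)(C)O1` gives 3 nM. Compound 3 `CC1(C)Cc2c(sc(NC(=O)[C@H](O)C(C)(C)C)c2C(N)=O)C(C)(C)O1` gives 127 nM. On these numbers compound 3 stands second highest of the three: its nearest neighbour is compound 1, and the two lie within the scatter of each other (a 1.5-fold lower number from compound 1 to compound 3 (0.17 log units; within the scatter)), while compound 2 lies far from it (a 42-fold higher number from compound 2 to compound 3 (1.63 log units; beyond the scatter)).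

The unmeasured compound 4 `CC1(C)Cc2c(sc(NC(=O)c3cc(C(F)(F)F)n[nH]3)c2C(N)=O)C(C)(C)O1` differs from compound 3 in one place: 3-(trifluoromethyl)-1H-pyrazol-5-yl in place of 1-hydroxy-2,2-dimethylpropyl on a carbonyl carbon. The step that bears most directly on this change is the one between the plain pyrazole and the hydroxy-dimethylpropyl chain, a 42-fold higher number from compound 2 to compound 3 (1.63 log units; beyond the scatter), which was large. For the measured compounds named here, the change from compound 3 to compound 4 brings back a pyrazole, now carrying a trifluoromethyl group; no measured pair shows what that group by itself does on this ring.

A large step in the same direction as the return to a pyrazole is therefore expected, a 25-fold lower number from compound 3 to compound 4 (1.40 log units; beyond the scatter), giving a markedly lower number. Compound 4 is estimated at 5 nM, with a range from 1.5 nM to 25 nM.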

Compound 4, half-maximal effective concentration: 3 nM
Compound 4: the middle estimate sits 1.7-fold (0.22 log units) above what was measured; the range from low to high includes it.
By their numbers in this assay, from the lowest: compounds 2 and 4 (each within the scatter of the next); then compounds 3 and 1 (each within the scatter of the next).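

The missing pair is now available: in (this assay), trifluoromethyl in place of hydrogen on an aromatic carbon of the pyrazole gives no change at the digits printed from compound 2 to compound 4 (within the scatter), so this position accepts that larger group with no readable effect on the number. The gain seen with the plain pyrazole also survives on the substituted ring, with a 42-fold lower number from compound 3 to compound 4 (1.63 log units; beyond the scatter) and a 63-fold lower number from compound 1 to compound 4 (1.80 log units; beyond the scatter), so both steps remain large and match in size those seen with compound 2. Nothing measured here explains why the added group leaves the number in place.

Among the compounds shown, this ring carbon carries only hydrogen or trifluoromethyl, so it remains open whether a methyl group, a chlorine atom, an amine or a carboxylic acid at the same place would also leave the number unchanged. As far as these compounds go, it is also open whether the hydrogen on the pyrazole nitrogen is needed, which a pyrazole with a methyl group on that nitrogen could test, and whether another five-membered ring, such as an imidazole, could replace the pyrazole.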